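The source may hold more compounds than are shown below. What is called first, only, known or untested is meant among the compounds shown, and "the series" means these compounds.

Measured so far:
compound 1, `CCOC(=O)/C=C/c1cnc(Nc2ccc(C#N)cc2)nc1Oc1c(C)cc(C#N)cc1C` — > 227 nM
compound 2, `Cc1cc(C#N)cc(C)c1Oc1nc(Nc2ccc(C#N)cc2)ncc1/C=C/C(=O)NCC1CCN(S(C)(=O)=O)CC1` — > 171 nM

In an ADME assay on TZM cells (Homo sapiens) for cytotoxicity, with a stated time of 1 days (a lower number here means that less compound is tolerated, a higher number that more compound is tolerated), compound 1 gives only a limit, > 227 nM. Compound 2 likewise gives only a limit in this assay, > 171 nM. For the measured compounds named here, the one measured step, a step that the two limits leave unreadable from compound 1 to compound 2, cannot be read because the limit of > 171 nM in this assay, at which 1 of the 2 values shown sits, and the limit of > 227 nM in this assay, at which 1 of the 2 values shown sits, are both limits rather than numbers. Going by the values given here, compound 1 thus stands at a limit, and the single other value shown is a limit too.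

Compound 3, `Cc1cc(C#N)cc(C)c1Oc1nc(Nc2ccc(C#N)cc2)ncc1/C=C/C(=O)N1CCN(C(=O)C(F)(F)F)CC1`, has not been measured in this assay. It differs from compound 1 by 4-((trifluoromethyl)carbonyl)piperazin-1-yl in place of ethoxy on a carbonyl carbon. The change from compound 1 to compound 2 also replaces the ethoxy on the carbonyl carbon with a larger group, and that step gave no readable size, so no size is expected here either. Compound 3 is expected to give about 300 nM, somewhere between 150 nM and 1000 nM, most likely again as a limit. The expected step is a step that the limit leaves unreadable from compound 1 to compound 3, which is estimated to lie within the scatter.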

Compound 3, half-maximal cytotoxic concentration: > 174 nM
Compound 3 ended at the assay's limit; the forecaster's own chance of this, stated with the estimate: 70%; the middle value lies beyond the limit too.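

In this assay compound 3 gives > 174 nM, which is a limit and not a number. For the compounds shown here, compound 1 and compound 2 also stand at limits, so no step among the three can be read. The compounds shown leave open whether the group on the carbonyl carbon affects cytotoxicity at all.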